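Swapping the group on the amide carbonyl: compound 2 to compound 3

A few compounds are considered here, and "the series" means these few. Any claim that something is new, unique, unknown or untested is made for them only; others in the source may bear on it.

Compound 1 `COC(=O)C1=C(C)NC(C)=C(C(=O)OC)C1c1ccc(OCC(=O)N2CCN(C)CC2)c(OC)c1` gives 9100 nM in an assay on cells for inhibition of Voltage-gated L-type calcium channel (Rattus norvegicus), read by fluorescence and calcium flux, with stated times of 30 min and 2 min; a lower number here means a stronger inhibitor, a higher number a weaker inhibitor.
Compound 2 `COC(=O)C1=C(C)NC(C)=C(C(=O)OC)C1c1ccc(OCC(=O)n2ccnc2)c(OC)c1` gives 10100 nM in this assay.

Compound 2 holds the higher of the two numbers, but the step of a 1.1-fold higher number from compound 1 to compound 2 (0.05 log units; within the scatter) lies within the scatter, so compound 2 and compound 1 cannot be told apart on these numbers. Compound 3 `COC(=O)C1=C(C)NC(C)=C(C(=O)OC)C1c1ccc(OCC(=O)NC(C)(C)C)c(OC)c1` differs from compound 2 by (tert-butyl)amino in place of 1H-imidazol-1-yl on a carbonyl carbon. Among the compounds with values here, the only measured step that bears on this change is the one from compound 1 to compound 2, which also exchanged the group on that carbonyl carbon and gave a 1.1-fold higher number from compound 1 to compound 2 (0.05 log units; within the scatter), no movement beyond the scatter. On that single precedent, no step beyond the scatter is expected in this assay for this further exchange either. Compound 3 is therefore estimated to give 9000 nM, with a range from 3000 nM to 27000 nM. The expected step is a 1.1-fold lower number from compound 2 to compound 3 (0.05 log units; within the scatter).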

Compound 3, half-maximal inhibitory concentration: 2500 nM
For compound 3 the middle estimate is 3.6-fold (0.56 log units) above the measured one, and the stated range ends above it.
By their numbers in this assay, from the lowest: compound 3; then compounds 1 and 2 (each within the scatter of the next).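

In this assay the group on this carbonyl carbon proves able to move the number: (tert-butyl)amino in place of 1H-imidazol-1-yl gives a 4.0-fold lower number from compound 2 to compound 3 (0.61 log units; beyond the scatter) and in place of 4-methylpiperazin-1-yl gives a 3.6-fold lower number from compound 1 to compound 3 (0.56 log units; beyond the scatter), both beyond the scatter, whereas the exchange between the two earlier groups stayed within it. The entering group has no ring and carries one hydrogen-bond donor, where 1H-imidazol-1-yl has none. No measurement at hand accounts for this step.

From the compounds shown here alone, whether the lower number goes with the amide hydrogen or with the tert-butyl group stays open, as the change brings in both at once. How a smaller amine such as methylamino, or a dimethylamino group without the amide hydrogen, would read on the same carbonyl carbon is also unknown.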